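The compounds below may be only part of what the source reports. "The series", "measured", "known", "first", "only" and "open" are said of these compounds alone.

Compound 2 `c1ccc2c(c1)CN[C@@H](CN(CCCCNCC1CCCCC1)[C@H]1CCCc3cccnc31)C2` is the starting point of this step. In a functional assay on cells for agonist activity at C-X-C chemokine receptor type 4 (Homo sapiens), read by fluorescence and calcium flux, with a stated time of 90 s (on this read-out lower numbers stand for an effect already at smaller amounts and higher numbers for an effect only at larger amounts of compound), compound 2 reaches only the limit of the assay, > 30000 nM, and no number is known for it. Two neighbours are measured alongside it. Compound 1 `c1cncc(CNCCCCN(C[C@H]2Cc3ccccc3CN2)[C@H]2CCCc3cccnc32)c1` also stops at a limit in this assay, > 30000 nM. Compound 3 `C(=C/CN(C[C@H]1Cc2ccccc2CN1)[C@H]1CCCc2cccnc21)\CNCc1ccccn1` likewise gives only the limit > 30000 nM in this assay. Because of this, the steps among them cannot be sized: the step that the two limits leave unreadable from compound 1 to compound 2, the step that the two limits leave unreadable from compound 1 to compound 3 and the step that the two limits leave unreadable from compound 2 to compound 3 are all left unreadable by the two limits, as the limit of > 30000 nM in this assay, at which 3 of the 3 values shown sit, shows.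

The change to compound 4 `C(=C/CN(C[C@H]1Cc2ccccc2CN1)[C@H]1CCCc2cccnc21)\CNCc1cccnc1` is a group of 11 heavy atoms (9 carbon, 2 nitrogen; one six-membered aromatic ring with 1 hetero atom) in place of a group of 11 heavy atoms (10 carbon, 1 nitrogen; one six-membered non-aromatic ring of carbon only), on a saturated chain carbon bound to an amine nitrogen. Within the data shown here, the step that comes closest is the one from compound 2 to compound 3, where a group of the same size with one six-membered aromatic ring with one hetero atom replaced the cyclohexyl-bearing group, and that step stayed at the limit. Compound 4 is therefore expected to remain at or near the limit in this assay as well, with the step that the limit leaves unreadable from compound 2 to compound 4 estimated to be unreadable rather than a gain. The estimate for compound 4 is 50000 nM, in the range 20000 nM to 150000 nM.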

Compound 4, half-maximal effective concentration: > 30000 nM
Compound 4 was reported as a limit; the forecaster's own chance of this, stated with the estimate: 85%; the middle value is on the limit's open side.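

Compound 4 also stops at a limit in this assay, so its steps from compound 1, compound 2 and compound 3 cannot be read: the limit of > 30000 nM in this assay, at which 4 of the 4 values shown sit.

The compounds shown leave open whether any group on the saturated chain carbon bound to an amine nitrogen gives a readable value in this assay, and how compound 1, compound 2, compound 3 and compound 4 rank.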